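The source may hold more compounds than are shown below. What is called first, only, known or untested is meant among the compounds shown, and "the series" means these compounds.

In a functional assay on A549 cells (Homo sapiens) for cytotoxicity, read by MTT assay, with a stated time of 72 h (a higher number here means a weaker inhibitor, a lower number a stronger inhibitor), the measured compounds stand as follows
Compound 1 `Cc1oc2ncnc(Nc3cccc(Cl)c3)c2c1C(=O)NCCO` gives > 1000000 nM (a limit of the assay, not a number)
Compound 2 `Cc1oc2ncnc(Nc3ccc(OCc4cccc(F)c4)c(Cl)c3)c2c1C(=O)O` gives 21400 nM
Compound 3 `Cc1cccc(Nc2ncnc3oc(C)c(C(=O)O)c23)c1` gives 100000 nM

Compound 3, at 100000 nM, has the higher of the two numerical values, and compound 2, at 21400 nM, lies lower by more than the scatter. Compound 1 reports only a limit, > 1000000 nM.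

The next compound to consider is compound 4 `Cc1oc2ncnc(Nc3cccc(Cl)c3)c2c1C(=O)O`, which differs from compound 3 as follows: chloro in place of methyl on an aromatic carbon. This places chloro in place of methyl on an aromatic carbon, meta to a large group, turning 3-methylphenyl into 3-chlorophenyl.

Among the measured compounds shown here, no measured pair isolates this exchange, so the expectation in this assay rests on indirect evidence. Compound 2, which carries a chloro, gives 21400 nM, but it differs from compound 3 in more than that group. Compound 1, which also carries a chloro, gives only the limit > 1000000 nM. The expected change is therefore small and downward, and it may not exceed the scatter: a 1.7-fold lower number from compound 3 to compound 4 (0.22 log units; within the scatter) is the estimated step. For compound 4 the estimated value is 60000 nM, with an expected range of 15000 nM to 200000 nM.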

Compound 4, half-maximal inhibitory concentration: 95500 nM
Beside the measured number, compound 4's estimate is 1.6-fold (0.20 log units) below it; measured number inside the range.
By their numbers in this assay, from the lowest: compound 2; then compounds 4 and 3 (each within the scatter of the next). At a limit, above all of these: compound 1.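

In this assay, chloro in place of methyl on an aromatic carbon, meta to a large group, gives a step that stays within the scatter: a 1.0-fold lower number from compound 3 to compound 4 (0.02 log units; within the scatter). At this position, then, 3-methylphenyl and 3-chlorophenyl cannot be told apart, whereas the two other single changes around compound 4 do register, with hydrogen in place of (3-fluorobenzyl)oxy on an aromatic carbon giving a 4.5-fold higher number from compound 2 to compound 4 (0.65 log units; beyond the scatter) and hydroxy in place of (2-hydroxyethyl)amino on a carbonyl carbon giving an at least 10-fold lower number from compound 1 to compound 4 (1.01 log units; beyond the scatter). The last of these steps rests on a limit of the assay and not on a number: the limit of > 1000000 nM in this assay, at which 1 of the 4 values shown sits.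

The compounds shown leave open whether other groups at this position, such as methoxy, fluoro or an amine, would also stay within the scatter, and whether methyl and chloro would still match with the (3-fluorobenzyl)oxy group present. They also leave open how the number would respond on the carbonyl carbon to a methyl ester or a plain amide, since only hydroxy and (2-hydroxyethyl)amino appear there.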